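Swapping a fluorinated ether tail on a shared core

The source may hold more compounds than are shown below. What is called first, only, known or untested is meant among the compounds shown, and "the series" means these compounds.

Compound 1 `O=C(O)Cn1nc(Cc2nc3cc(Cl)c(OCC(F)F)cc3[nH]2)c2ccccc2c1=O` was tested in a functional assay on CHO cells for antagonist activity at sphingosine 1-phosphate receptor 2 (Homo sapiens), read by calcium flux (a lower number here means a stronger inhibitor, a higher number a weaker inhibitor), where compound 1 gives 12 nM. This is the higher of the two numbers recorded so far. The other measured compound, compound 2 `O=C(O)Cn1nc(Cc2cn3cc(OCC4CC4)c(Cl)cc3n2)c2ccccc2c1=O`, gives in this assay a value of 9 nM, and the gap between compound 1 and compound 2 lies within the usual scatter of this kind of measurement, so the two cannot be told apart on potency.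

The next compound to consider is compound 3 `O=C(O)Cn1nc(Cc2nc3cc(Cl)c(OC(F)(F)F)cc3[nH]2)c2ccccc2c1=O`, which differs from compound 1 in a single place: trifluoromethyl in place of 2,2-difluoroethyl on an oxygen on an aromatic ring. Among the compounds with values here, both the leaving and the entering groups are small, uncharged and carry no hydrogen-bond donors or acceptors, and no measured pair shows what such an exchange does to potency here.

With nothing more to go on than this one position, the expected step from compound 1 to compound 3 in this assay is no change at the digits printed from compound 1 to compound 3 (within the scatter), which is not beyond the scatter. Compound 3 is therefore estimated to give 12 nM in this assay, with a likely range from 5 nM to 30 nM.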

Compound 3, half-maximal inhibitory concentration in the sphingosine 1-phosphate receptor 2 assay: 31 nM
Compound 3: the middle estimate sits 2.6-fold (0.41 log units) below what was measured; measured number outside the range, above it.
By their numbers in the sphingosine 1-phosphate receptor 2 assay, from the lowest: compounds 2 and 1 (each within the scatter of the next); then compound 3.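

Until now nothing showed whether the group on this oxygen on an aromatic ring mattered for potency, and here a change between two groups of equal heavy-atom count, both uncharged, has a measurable effect in the sphingosine 1-phosphate receptor 2 assay: a 2.6-fold higher number from compound 1 to compound 3 (0.41 log units; beyond the scatter). So this position is not indifferent to small exchanges, and on the shared core, trifluoromethyl is the less favourable of the two groups for inhibition. The same exchange also shifts a second property: in a physicochemical assay for lipophilicity, at pH 7.4 (on this read-out higher numbers stand for higher lipophilicity and lower numbers for lower lipophilicity), compound 1 gives 1.97 and compound 3 gives 2.54, a number 0.57 log units higher from compound 1 to compound 3 (beyond the scatter).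

A single pair cannot show whether the two shifts are linked, and since the exchange alters the carbon count and the fluorine count together, it cannot show which of the two matters. A plain methyl or ethyl on the same oxygen, or a longer chain such as 2,2,2-trifluoroethyl, would help to separate these, but the compounds shown leave open how any of them would behave.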